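Fluorine on the Outer Ring of a Receptor Agonist

The compounds below may be only part of what the source reports. "The series", "measured", "known", "first", "only" and "open" are said of these compounds alone.

Compound 1: `Cc1ccccc1-c1cccc(COc2ccc([C@H](CC(=O)O)c3nccn3C)cc2)c1` — 43 nM
Compound 2: `CCc1ccccc1-c1cccc(COc2ccc([C@H](CC(=O)O)c3nccn3C)cc2)c1` — 48 nM

In an assay on CHO cells for agonist activity at Free fatty acid receptor 1 (Homo sapiens), read by luminescence, with a stated time of 20 s, in the presence of a further agent that is not named here (on this read-out lower numbers stand for an effect already at smaller amounts and higher numbers for an effect only at larger amounts of compound), compound 1 gives 43 nM, the lowest of the two numbers, and compound 2 stands nearest at 48 nM; the step of a 1.1-fold higher number from compound 1 to compound 2 (0.05 log units; within the scatter) lies within the scatter. Compound 3 `Cc1ccc(F)cc1-c1cccc(COc2ccc([C@H](CC(=O)O)c3nccn3C)cc2)c1` differs from compound 1 by fluoro in place of hydrogen on an aromatic carbon. Among the measured compounds shown here, no measured step touches this ring position: the only step known changed a different part of the molecule and stayed within the scatter, so nothing points to a move in either direction. Compound 3 is therefore expected to give about 40 nM (range 15 nM to 110 nM), an estimated step of a 1.1-fold lower number from compound 1 to compound 3 (0.03 log units; within the scatter) that stays within the scatter.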

Compound 3, half-maximal effective concentration: 36 nM
Compound 3: the middle estimate sits 1.1-fold (0.05 log units) above what was measured, and the stated range covers the measured number.
By their numbers in this assay, from the lowest: compounds 3, 1 and 2 (each within the scatter of the next).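

Putting fluoro on this aromatic carbon, para to the methyl group, gives a 1.2-fold lower number from compound 1 to compound 3 (0.08 log units; within the scatter) and so leaves the number in this assay practically unmoved. The 5-fluoro-2-methylphenyl group in place of 2-ethylphenyl gives a 1.3-fold lower number from compound 2 to compound 3 (0.12 log units; within the scatter) as well, so across compounds 1, 2 and 3 this outer ring has taken two different changes with no step beyond the scatter. As far as these compounds go, whether chloro, methoxy or an amine on this same carbon would also leave the number in place stays open. Nothing available offers a reason for these numbers.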